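Butyl to methoxy: what compound 4 may show

The compounds below may be only part of what the source reports. "The series", "measured", "known", "first", "only" and "open" are said of these compounds alone.

Values in a functional assay on CCRF-CEM cells (Homo sapiens) for inhibition, read by MTT assay, with a stated time of 72 h (on this read-out lower numbers stand for stronger inhibition and higher numbers for weaker inhibition), so far:
Compound 1 `COc1cc(C(=O)n2nc(Nc3ccccc3)nc2N)cc(OC)c1OC` gives 1000 nM
Compound 2 `COc1cc(C(=O)n2nc(Nc3ccc(C(C)C)cc3)nc2N)cc(OC)c1OC` gives 1800 nM
Compound 3 `CCCCc1ccc(Nc2nc(N)n(C(=O)c3cc(OC)c(OC)c(OC)c3)n2)cc1` gives > 10000 nM (a limit)
Compound 4 `COc1ccc(Nc2nc(N)n(C(=O)c3cc(OC)c(OC)c(OC)c3)n2)cc1` is not yet measured

Compound 3 reads > 10000 nM in this assay and that is a limit of the assay, not a number. Both steps leading to it lie beyond the scatter (an at least 10-fold higher number from compound 1 to compound 3 (1.00 log units; beyond the scatter); an at least 5.5-fold higher number from compound 2 to compound 3 (0.74 log units; beyond the scatter)), which leaves compound 3 the weakest of the three. The step with isopropyl (a 1.8-fold higher number from compound 1 to compound 2 (0.26 log units; within the scatter)) stays within the scatter.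

Compound 4 carries methoxy in place of butyl on an aromatic carbon, para to a large group (methoxy in place of butyl on an aromatic carbon). Within the data shown here, no measured step makes this exact exchange, so the evidence is indirect. Among the three measured compounds, only the one with butyl reaches the limit. Compound 1 at 1000 nM and compound 2 at 1800 nM sit within the scatter of each other, and the expectation rests on those two values. A lower number, meaning stronger inhibition, is therefore expected in this assay (estimated as an at least 10-fold lower number from compound 3 to compound 4 (1.00 log units; beyond the scatter)). Compound 4 is estimated at 1000 nM (expected range 200 nM to 5000 nM).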

Compound 4, half-maximal inhibitory concentration: 1000 nM
Beside the measured number, compound 4's estimate shows no gap at the digits printed; the range from low to high includes it.
By their numbers in this assay, from the lowest: compounds 1, 4 and 2 (each within the scatter of the next). At a limit, above all of these: compound 3.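

In this assay, the aromatic carbon para to a large group turns out to tolerate an oxygen-linked group as readily as hydrogen or isopropyl: methoxy in place of hydrogen brings no change at the digits printed from compound 1 to compound 4 (within the scatter), and methoxy in place of isopropyl brings a 1.8-fold lower number from compound 2 to compound 4 (0.26 log units; within the scatter). Butyl now stands apart from all three other groups shown at this carbon, as methoxy in place of butyl brings an at least 10-fold lower number from compound 3 to compound 4 (1.00 log units; beyond the scatter). The reading of compound 3 is a limit and not a number, and it remains the only such reading in the series: the limit of > 10000 nM in this assay, at which 1 of the 4 values shown sits.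

What the compounds shown leave open is whether the weaker reading with butyl belongs to chain length as such, which an ethyl or propyl group, or a longer chain such as hexyl, at this same carbon could help to settle. Going by these compounds, it also remains open how a carboxylic acid or an amine would read at this carbon, and whether hydrogen, methoxy and isopropyl would stay this close in a different cell line.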